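Methylating the amine nitrogen of a weak transporter inhibitor

The compounds below may be only part of what the source reports. "The series", "measured", "known", "first", "only" and "open" are said of these compounds alone.

The study concerns a small set of diaryl ethers built on the shared core of compound 1 `COc1cc(Cl)ccc1Oc1ccncc1CN(C)C`, which in an assay on HEK293 cells for inhibition of sodium-dependent dopamine transporter (Homo sapiens) (a higher number here means a weaker inhibitor, a lower number a stronger inhibitor), gives 10200 nM, a figure at the weak end of the scale. Compound 2 `CNCc1cnc(C)cc1Oc1ccc(Cl)cc1OC` carries a methylamino-methyl group on its core; in this assay compound 2 has "not determined" (no result reported), so it stands on no number of its own. Compound 3 `COc1cc(Cl)ccc1Oc1cc(C)ncc1CN(C)C` differs from compound 2 by methyl in place of hydrogen on an amine nitrogen. Among the compounds with values here, no measured pair tracks that exact change, so its effect is unknown. A change of this kind is expected to move the value little, perhaps within the usual scatter, with a modest weakening considered somewhat more likely than a strengthening. Compound 3 is therefore estimated to give 9000 nM in this assay, within a range from 2500 nM to 32000 nM.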

Compound 3, half-maximal inhibitory concentration: 5040 nM
Beside the measured number, compound 3's estimate is 1.8-fold (0.25 log units) above it, within the range that was stated.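

In this assay, within the data shown here, the one step that can be read is a 2.0-fold lower number from compound 1 to compound 3 (0.31 log units; beyond the scatter), so a methyl in place of hydrogen on an aromatic carbon of the shared core gives a modest strengthening, the first sign that this carbon responds to substitution. From the compounds shown here alone, the methylation of the amine nitrogen, the step from compound 2 to compound 3, cannot be read: compound 2 has no number, and the effect of that change remains unknown. No measurement shown offers an explanation for the shift at the aromatic carbon.

Going by these compounds, whether an ethyl group or a chlorine on that same aromatic carbon would move the number further stays open. So does the effect of a primary amine in place of the dimethylamino group.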